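The compounds below may be only part of what the source reports. "The series", "measured", "known", "first", "only" and "open" are said of these compounds alone.

In a functional assay on MCF7 cells (Homo sapiens) for cytotoxicity, read by ELISA, with a stated time of 4 days (a higher number here means a weaker inhibitor, a lower number a stronger inhibitor), compound 1 (`Cc1ccsc1-c1cc(-c2ccco2)cc(-c2ccccc2Cl)n1`) gives 14200 nM, compound 2 (`Cc1ccsc1-c1cc(-c2ccco2)cc(-c2ccc(Cl)cc2)n1`) gives 890 nM and compound 3 (`Cc1ccccc1-c1cc(-c2ccoc2)cc(-c2ccc(Cl)s2)n1`) gives 1430 nM. Compound 3 thus holds the second highest of the three numbers, within the scatter of compound 2 and well under compound 1. Compound 4 (`Clc1cccc(-c2cc(-c3ccoc3)cc(-c3ccc(Cl)s3)n2)c1`) differs from it in one place, next to the ring nitrogen: 3-chlorophenyl in place of 2-methylphenyl on an aromatic carbon. Among the measured compounds shown here, only one measured step bears on this change, and only indirectly. Putting 4-chlorophenyl in place of 2-chlorophenyl gave a 16-fold lower number from compound 1 to compound 2 (1.20 log units; beyond the scatter), a large step. For the measured compounds named here, compound 1 and compound 2 carry other groups than compound 3, however, and no 3-chlorophenyl compound has a measured number yet. A step of that size is not expected in this assay because compound 3 already stands at 1430 nM with its 2-methylphenyl. A small lowering is expected instead, and the estimated step is a 1.8-fold lower number from compound 3 to compound 4 (0.25 log units; within the scatter). For compound 4 the expected value is 800 nM, with an estimated range from 250 nM to 2500 nM.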

Compound 4, half-maximal inhibitory concentration: 2920 nM
The estimate for compound 4 lay 3.7-fold (0.56 log units) below the measured number; measured number outside the range, above it.
By their numbers in this assay, from the lowest: compounds 2 and 3 (each within the scatter of the next); then compound 4; then compound 1.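

In this assay, 3-chlorophenyl in place of 2-methylphenyl next to the ring nitrogen gives a 2.0-fold higher number from compound 3 to compound 4 (0.31 log units; beyond the scatter). The number thus rises with this change, so the position responds to the phenyl group it carries in compounds with the 5-chlorothiophen-2-yl and furan-3-yl groups too, though the step is modest where a 16-fold lower number from compound 1 to compound 2 (1.20 log units; beyond the scatter) was large. No measurement shown here accounts for the rise. The compounds shown leave open whether 4-chlorophenyl would give a lower number than 3-chlorophenyl when the 5-chlorothiophen-2-yl and furan-3-yl groups are present. They also leave open how an amine or a carboxylic acid on this phenyl ring would read in the same cells.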